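Benzylamino swap at the weak end of the series

The source may hold more compounds than are shown below. What is called first, only, known or untested is meant among the compounds shown, and "the series" means these compounds.

Values in a functional assay on L6 cells (Rattus norvegicus) for inhibition (a higher number here means a weaker inhibitor, a lower number a stronger inhibitor), by compound:
- compound 1 `Cc1ccc(CN(C)C(=O)c2nn(-c3ccc(F)cc3)c(OC[C@@H](O)C[C@@H](O)CC(=O)O)c2C(C)C)cc1` gives 1250 nM 
- compound 2 `CC(C)c1c(C(=O)N2CCC[C@H](c3ccccc3)C2)nn(-c2ccc(F)cc2)c1OC[C@@H](O)C[C@@H](O)CC(=O)O` gives 1110 nM 
- compound 3 `COc1cccc(CNC(=O)c2nn(-c3ccc(F)cc3)c(OC[C@@H](O)C[C@@H](O)CC(=O)O)c2C(C)C)c1` gives 8750 nM 

In this assay compound 3 has the highest number of the three at 8750 nM and is the weakest inhibitor measured so far. For the measured compounds named here, the other two do not separate, with a 1.1-fold lower number from compound 1 to compound 2 (0.05 log units; within the scatter) as the only step between them.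

Next is compound 4 `CC(C)c1c(C(=O)NCc2ccccc2Cl)nn(-c2ccc(F)cc2)c1OC[C@@H](O)C[C@@H](O)CC(=O)O` and the change from compound 3 is 2-chlorophenyl in place of 3-methoxyphenyl on a saturated chain carbon bound to an amide-type nitrogen in which 2-chlorophenyl stands in place of 3-methoxyphenyl on a saturated chain carbon bound to an amide-type nitrogen.

Going by the values given here, two measured steps bear on this only loosely. Both a 7.0-fold higher number from compound 1 to compound 3 (0.85 log units; beyond the scatter) and a 7.9-fold higher number from compound 2 to compound 3 (0.90 log units; beyond the scatter) exchange the whole group on the carbonyl carbon. Among the compounds with values here, no measured pair changes only the substituted phenyl, and compound 4 keeps a substituted benzylamino group like that of compound 3, so neither size carries over directly. No step beyond the scatter is expected in this assay and there is only a slight lean towards a lower number.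

The expected step is a 1.6-fold lower number from compound 3 to compound 4 (0.20 log units; within the scatter) on this estimate. Compound 4 is estimated at 5500 nM with an expected range from 2000 nM to 15000 nM as a working figure.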

Compound 4, half-maximal inhibitory concentration: 8450 nM
Compound 4: middle estimate off by 1.5-fold (0.19 log units), on the low side, within the range that was stated.
By their numbers in this assay, from the lowest: compounds 2 and 1 (each within the scatter of the next); then compounds 4 and 3 (each within the scatter of the next).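

Notes on the benzylamino group: in this assay, the change on a saturated chain carbon bound to an amide-type nitrogen gives a 1.0-fold lower number from compound 3 to compound 4 (0.02 log units; within the scatter) and is the first measured step confined to the substituted phenyl, so 2-chlorophenyl and 3-methoxyphenyl do not separate here. The gap to the other two compounds also holds for this second benzylamino group, with a 7.6-fold higher number from compound 2 to compound 4 (0.88 log units; beyond the scatter) and then a 6.8-fold higher number from compound 1 to compound 4 (0.83 log units; beyond the scatter) as the two steps, and none of the four compounds goes against this split between the two substituted benzylamino amides carrying the amide hydrogen and the two carbonyl groups without it. No supporting data bear on why this substitution leaves the number unmoved or why the split appears.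

Open, on these data alone, is whether the split follows the amide hydrogen or the rest of the group on the carbonyl carbon, which methyl(2-chlorobenzyl)amino, differing from compound 4 only by that methyl on nitrogen, would address directly. Also open, as far as these compounds go, is whether any substituent on this phenyl moves the number at all, as an unsubstituted benzylamino group or a 4-methylbenzylamino group set against compound 4 would show.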